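An aromatic group exchanged on compound 3

This account rests on a few compounds, and the source may have more. Where it says the series, first, only, none or still open, it means among the compounds named here.

In a functional assay on HL60/MX2 cells (Homo sapiens) for antiproliferative activity, read by MTT assay, with a stated time of 48 h (a lower number here means a stronger inhibitor, a higher number a weaker inhibitor), compound 3 `CN(C)CCCCn1c(N)c(-c2nc3ccccc3s2)c2nc(C#N)c(C#N)nc21` gives 2140 nM. Compound 2 `CN(C)CCCn1c(N)c(-c2nc3ccccc3s2)c2nc(C#N)c(C#N)nc21` gives 1310 nM, and the two lie within the scatter of each other, a 1.6-fold higher number from compound 2 to compound 3 (0.21 log units; within the scatter). Differing from compound 3 in both the chain and the aromatic group, compound 1 `CCCn1c(N)c(-c2nc3ccccc3[nH]2)c2nc(C#N)c(C#N)nc21` gives > 50000 nM, a limit rather than a number. Compound 4 `CN(C)CCCCn1c(N)c(-c2nc3ccccc3n2C)c2nc(C#N)c(C#N)nc21` has 1-methyl-1H-benzimidazol-2-yl in place of 1,3-benzothiazol-2-yl on an aromatic carbon. Among the measured compounds shown here, no measured step isolates this exchange, since the only one, a 1.6-fold higher number from compound 2 to compound 3 (0.21 log units; within the scatter), lies in the chain. Only a slight lean towards a higher number is therefore expected, an estimated 1.6-fold higher number from compound 3 to compound 4 (0.21 log units; within the scatter). For compound 4 the expected value is 3500 nM, with an estimated range of 900 nM to 15000 nM.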

Compound 4, half-maximal inhibitory concentration: 2580 nM
The estimate for compound 4 lay 1.4-fold (0.13 log units) above the measured number; measured number inside the range.
By their numbers in this assay, from the lowest: compounds 2, 3 and 4 (each within the scatter of the next). At a limit, above all of these: compound 1.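

In this assay the exchange of 1,3-benzothiazol-2-yl for 1-methyl-1H-benzimidazol-2-yl on this aromatic carbon gives a 1.2-fold higher number from compound 3 to compound 4 (0.08 log units; within the scatter) and so separates the two groups by nothing beyond the scatter. This is the first step shown at this position, and the position tolerates this exchange with the 4-(dimethylamino)butyl group held constant. Nothing at hand explains this result. Compound 1 gives > 50000 nM as a limit, and it differs from compound 4 in both the chain and the aromatic group, so neither change can be read from it. From the compounds shown here alone, how a phenyl or a 1,3-benzoxazol-2-yl would behave on this carbon remains open.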